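Swapping fluoro for dimethylamino on the most active compound

The source may report more compounds than this note shows. Statements on the series, on what has been measured and on what is new or still open speak of the compounds shown alone.

In a functional assay on A549 cells (Homo sapiens) for inhibition, read by sulforhodamine B assay (a lower number here means a stronger inhibitor of growth, a higher number a weaker inhibitor of growth), compound 1 `Fc1ccc(-c2ccc(-c3ccc(-c4nc5ccccc5[nH]4)cc3)cc2)cc1` gives 33200 nM and compound 2 `Clc1cccc(-c2ccc(-c3ccc(-c4nc5ccccc5[nH]4)cc3)cc2)c1` gives 31100 nM. Compound 3 `Oc1cccc2[nH]c(-c3ccc(-c4ccc(-c5ccc(F)cc5)cc4)cc3)nc12` gives 170 nM, the lowest number of the three. Compound 4 `CN(C)c1ccc(-c2ccc(-c3ccc(-c4nc5c(O)cccc5[nH]4)cc3)cc2)cc1` keeps the hydroxy group of compound 3 but has dimethylamino in place of fluoro on an aromatic carbon.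

Among the measured compounds shown here, two measured steps bear on this change. For the measured compounds named here, putting 3-chlorophenyl in place of 4-fluorophenyl gave a 1.1-fold lower number from compound 1 to compound 2 (0.03 log units; within the scatter), the only measured swap at this end group. Adding the hydroxy group gave a 200-fold lower number from compound 1 to compound 3 (2.29 log units; beyond the scatter), a large step, and compound 4 retains that group. Going by the values given here, no measured compound carries dimethylamino, and the one swap was made without the hydroxy group, so this evidence is thin. A change beyond the scatter is therefore not expected, though one cannot be ruled out. The expected step is a 1.2-fold higher number from compound 3 to compound 4 (0.07 log units; within the scatter). For compound 4 the estimate is 200 nM, with an expected range from 60 nM to 800 nM.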

Compound 4, concentration for 50% growth inhibition: 7100 nM
Beside the measured number, compound 4's estimate is 36-fold (1.55 log units) below it; measured number above the stated range.
By their numbers in this assay, from the lowest: compound 3; then compound 4; then compounds 2 and 1 (each within the scatter of the next).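

With the hydroxy group present, dimethylamino in place of fluoro gave a 42-fold higher number from compound 3 to compound 4 (1.62 log units; beyond the scatter) in this assay, so this end position, para to a large group, is far from indifferent to what sits on it. Among the compounds shown here, the only earlier swap here, made without the hydroxy group, gave a 1.1-fold lower number from compound 1 to compound 2 (0.03 log units; within the scatter), and that near-silent result did not reveal how much a change at this position can cost. No measurement offered here explains the loss of growth inhibition.

Dimethylamino appears only alongside the hydroxy group, so it remains open whether the same swap would cost as much without that group. From the compounds shown here alone, how a methoxy group or a primary amine would fare at this position also remains open, as does whether any replacement for fluoro can keep the number of compound 3.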